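Methoxy on the phenyl of compound 1

The source may hold more compounds than are shown below. What is called first, only, known or untested is meant among the compounds shown, and "the series" means these compounds.

Going by the values given here, in a functional assay on U-87MG ATCC cells (Homo sapiens) for antiproliferative activity, read by MTT assay, with a stated time of 48 h (on this read-out lower numbers stand for stronger inhibition and higher numbers for weaker inhibition), compound 1 `O=C(/C=C\Nc1ccc(Cl)cc1)c1cn(-c2ccccc2)nc1-c1ccccc1` gives 11400 nM as the only exact number so far. Compound 2 `COc1ccc(N/C=C\C(=O)c2cn(-c3ccccc3)nc2-c2ccccc2)cc1` gives > 50000 nM as its result, and that is a limit of the assay and not a number.

Compound 3 `COc1ccc(-c2nn(-c3ccccc3)cc2C(=O)/C=C\Nc2ccc(Cl)cc2)cc1` is still to be tested. Its change from compound 1 (methoxy in place of hydrogen on an aromatic carbon) is methoxy in place of hydrogen on an aromatic carbon, para to a large group, which reads as phenyl to 4-methoxyphenyl.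

Among the compounds with values here, one measured step bears on this, and only weakly. It is an at least 4.3-fold higher number from compound 1 to compound 2 (0.64 log units; beyond the scatter) and it puts methoxy in place of chloro, not in place of hydrogen, at another place in the molecule. Within the data shown here, with compound 2 as the sole guide through an at least 4.3-fold higher number from compound 1 to compound 2 (0.64 log units; beyond the scatter) as its step, a smaller move in the same direction is expected in this assay and it may stay within the scatter. The expected move is a 1.5-fold higher number from compound 1 to compound 3 (0.17 log units; within the scatter) as a rough estimate. For compound 3 the estimated value is 17000 nM with 5500 nM to 50000 nM as the expected range.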

Compound 3, half-maximal inhibitory concentration: 8860 nM
Compound 3: the middle estimate sits 1.9-fold (0.28 log units) above what was measured, and the stated range covers the measured number.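

In this assay, going by these compounds alone, the change from phenyl to 4-methoxyphenyl gives a 1.3-fold lower number from compound 1 to compound 3 (0.11 log units; within the scatter), so methoxy in place of hydrogen at this position, para to a large group, produces no step that stands out from the scatter. The earlier step, methoxy in place of chloro at another place in the molecule, gives an at least 4.3-fold higher number from compound 1 to compound 2 (0.64 log units; beyond the scatter), so the two changes that introduce methoxy do not read alike in this series, although they also differ in the group that leaves. Compound 2 gives > 50000 nM, a limit of the assay and not a number, so that earlier step has no fixed size.

No measured property shown here accounts for the difference between the two steps. The compounds shown leave open whether other groups on this phenyl, such as a hydroxyl, an amine or a carboxylic acid, would move the number beyond the scatter, and whether methoxy would read the same at any other position on that ring.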